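Dichlorophenyl to nitrophenyl: expecting a higher tolerated concentration

The compounds below may be only part of what the source reports. "The series", "measured", "known", "first", "only" and "open" are said of these compounds alone.

Measured in an ADME assay on cells (Rhabdomyosarcoma cell, Homo sapiens) for cytotoxicity, read by MTT assay, with a stated time of 72 h; a higher number here means that more compound is tolerated, a lower number that less compound is tolerated:
Compound 1 `Clc1ccc(/C=N/c2sc3c(c2-c2nc4ccccc4s2)CCC3)cc1`: 342 ug/mL
Compound 2 `Clc1ccc(/C=N/c2sc3c(c2-c2nc4ccccc4s2)CCC3)c(Cl)c1`: 160 ug/mL
Compound 3 `Clc1ccc(/C=N/c2sc3c(c2-c2nc4ccccc4s2)CCCC3)c(Cl)c1`: 56.6 ug/mL

Compound 3 has the lowest number of the three, with compound 2 nearest and compound 1 furthest. Compound 4 `O=[N+]([O-])c1ccc(/C=N/c2sc3c(c2-c2nc4ccccc4s2)CCCC3)cc1` differs from it by 4-nitrophenyl in place of 2,4-dichlorophenyl on a carbon with a double bond to nitrogen. Within the data shown here, only one measured step changes a single place: a 2.1-fold lower number from compound 1 to compound 2 (0.33 log units; beyond the scatter), where adding a chloro group lowered the number. Compounds 2 and 3 differ elsewhere in the shared core, and compound 3 gives the lower value. Among the measured compounds shown here, no measured step involves a nitro group, so the entering group's effect is unknown. Because a 2.1-fold lower number from compound 1 to compound 2 (0.33 log units; beyond the scatter) fell when chloro entered, removing both chloro groups is expected to raise the number, by about a 1.9-fold higher number from compound 3 to compound 4 (0.29 log units; within the scatter). Compound 4 is therefore estimated at 110 ug/mL, within 40 ug/mL to 300 ug/mL.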

Compound 4, half-maximal cytotoxic concentration: 316 ug/mL
Beside the measured number, compound 4's estimate is 2.9-fold (0.46 log units) below it; measured number above the stated range.
By their numbers in this assay, from the lowest: compound 3; then compounds 2, 4 and 1 (each within the scatter of the next, the first and the last beyond it).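

Putting 4-nitrophenyl in place of 2,4-dichlorophenyl on the carbon with a double bond to nitrogen gives a 5.6-fold higher number from compound 3 to compound 4 (0.75 log units; beyond the scatter) in this assay. Among these compounds, this is the first measured step to replace the whole aromatic group at this position, and it shows that such a change can move the number beyond the scatter. Nothing measured here explains the rise.

As far as these compounds go, the step removes both chloro groups and adds the nitro group together, so their separate contributions remain open. An unsubstituted phenyl or a 4-aminophenyl group at this position on the same core could help separate them.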